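A few compounds are considered here, and "the series" means these few. Any claim that something is new, unique, unknown or untested is made for them only; others in the source may bear on it.

Among the measured compounds shown here, compound 3 `O=C(NO)c1ccc(CNCc2nc(-c3ccc(C(F)(F)F)cc3)no2)cc1` gives 1360 nM in an assay on isolated protein for inhibition of histone deacetylase 8 (Homo sapiens), read by fluorescence, with a stated time of 20 min (a higher number here means a weaker inhibitor, a lower number a stronger inhibitor), the only number among the three values shown. Compound 1 `Nc1ccccc1NC(=O)c1ccc(CNCc2nc(-c3ccc(C(F)(F)F)cc3)no2)cc1` gives > 10000 nM, which is a limit of the assay. Compound 2 `Nc1ccccc1NC(=O)c1ccc(CNCc2nc(-c3cccs3)no2)cc1` likewise gives > 10000 nM, again a limit. The change to compound 4 `O=C(NO)c1ccc(CNCc2nc(-c3ccc([N+](=O)[O-])cc3)no2)cc1` is nitro in place of trifluoromethyl on an aromatic carbon. Neither measured step varies this position: an at least 7.3-fold lower number from compound 1 to compound 3 (0.86 log units; beyond the scatter) concerns the amide end, and a step that the two limits leave unreadable from compound 1 to compound 2 swaps the whole aryl group yet stays unreadable because both values sit at the limit of > 10000 nM in this assay, at which 2 of the 3 values shown sit. For the measured compounds named here, with no step that speaks to this substituent, the author expects in this assay a change no larger than the scatter, a 1.1-fold lower number from compound 3 to compound 4 (0.05 log units; within the scatter). Compound 4 is therefore estimated at 1200 nM, within 400 nM to 3500 nM.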

Compound 4, half-maximal inhibitory concentration: 380 nM
For compound 4 the middle estimate is 3.2-fold (0.50 log units) above the measured one; the measured number lies below the stated range.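

In this assay the substituent para to a large group proves able to move the number: nitro in place of trifluoromethyl gives a 3.6-fold lower number from compound 3 to compound 4 (0.55 log units; beyond the scatter) with the rest of the molecule unchanged. Among the compounds shown here, this is the first readable step at this position, as the earlier swap of the whole aryl group ran between two limits and stayed unreadable. Nothing measured here accounts for the step.

On these data alone, whether an amine or a nitrile at this place would lower the number further remains open. So does whether nitro has any readable effect with 2-aminophenyl on the amide nitrogen.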